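This account rests on a few compounds, and the source may have more. Where it says the series, first, only, none or still open, it means among the compounds named here.

Compound 2 `COc1ccc2[nH]c(-c3nc(-c4ccc(Cl)cc4)no3)cc2c1` gives, in a functional assay on MIA PaCa-2 cells (Homo sapiens) for antiproliferative activity, read by WST assay, with a stated time of 72 h (on this read-out higher numbers stand for weaker inhibition and lower numbers for stronger inhibition), 22700 nM. Of the two numbers recorded this is numerically the lower, but compound 1 `COc1ccc2[nH]c(-c3nc(-c4ccccc4)no3)cc2c1`, which in this assay gives 32600 nM, stands close: the step of a 1.4-fold lower number from compound 1 to compound 2 (0.16 log units; within the scatter) lies within the scatter, so the two compounds cannot be told apart on these data. Compound 3 `Clc1ccc(-c2noc(-c3cc4cc(Cl)ccc4[nH]3)n2)cc1` has not yet been measured. The change from compound 2 to compound 3 is chloro in place of methoxy on an aromatic carbon. Going by the values given here, no measured step exchanges a methoxy for a chloro, so none bears directly on this change. Among the compounds with values here, the only step recorded, a 1.4-fold lower number from compound 1 to compound 2 (0.16 log units; within the scatter), also introduced a chloro, though at a different place, and it moved the number no further than repeated measurements of the same compound would. On that basis no step beyond the scatter is expected in this assay in either direction, and the expected step is a 1.1-fold lower number from compound 2 to compound 3 (0.05 log units; within the scatter). Compound 3 is therefore estimated at 20000 nM, with a range from 7000 nM to 60000 nM.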

Compound 3, half-maximal inhibitory concentration: > 50000 nM
Compound 3 ended at the assay's limit (the forecaster's own chance of this, stated with the estimate: 10%); at least 2.5-fold (0.39 log units) between middle value and limit.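

In this assay, going by these compounds alone, chloro in place of methoxy on the six-membered aromatic ring of the fused system gives an at least 2.2-fold higher number from compound 2 to compound 3 (0.34 log units; beyond the scatter), which makes it the first step in this short series to go beyond the scatter, and here a higher number means weaker inhibition. The earlier chloro step, at a different place, gave a 1.4-fold lower number from compound 1 to compound 2 (0.16 log units; within the scatter) and so stayed within the scatter; the group at this position therefore matters in a way the first pair could not reveal, and a chloro that makes no clear difference at one place cannot be assumed to do the same at another. The value of compound 3 is a limit of this assay and not a number, so the step has a known minimum but no known full size: the limit of > 50000 nM in this assay, at which 1 of the 3 values shown sits.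

The compounds shown leave open whether the methoxy helps inhibition or the chloro harms it, and a hydroxy group or an amine at this place would help separate those two readings. As far as these compounds go, it also remains open whether the same exchange would have a similar effect in compound 1, which lacks the chloro that compound 2 and compound 3 share on the outer ring.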